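The source may hold more compounds than are shown below. What is called first, only, known or untested is meant among the compounds shown, and "the series" means these compounds.

In an ADME assay on microsomes from liver (Mus musculus), read by LC-MS, using NADPH, tested at 10 uM (a higher number here means that the liver removes a larger share of the compound in one pass, a lower number that the liver removes a smaller share), three compounds have been measured so far. Compound 1 `Cc1ccccc1S(=O)(=O)N1CCN(c2cnc(C(=O)NCc3ccc(F)cc3)cn2)CC1` gives 0.95, and compound 3 `Cc1ccccc1S(=O)(=O)N1CC=C(c2ccc(C(=O)NCc3ccc(F)cc3)nn2)CC1` gives 0.94. Compound 2 `O=C(NCc1ccc(F)cc1)c1ccc(N2CCN(S(=O)(=O)c3ccccc3C(F)(F)F)CC2)nn1` gives 0.66, the lowest of the three, and its distance from each of the other two lies beyond the usual scatter. Compound 4 `O=C(NCc1ccc(F)cc1)c1ccc(N2CCN(S(=O)(=O)c3ccc(F)cc3C(F)(F)F)CC2)nn1` has not yet been measured. It differs from compound 2 in a single place: fluoro in place of hydrogen on an aromatic carbon. Within the data shown here, no pair of measured compounds differs in just this way, so no measured step of this kind is available to lean on. The expected step is a number 0.010 lower from compound 2 to compound 4 (within the scatter), a change not beyond the scatter in either direction. Compound 4 is therefore estimated to give 0.65, with a range from 0.5 to 0.8.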

Compound 4, hepatic extraction ratio: 0.84
The estimate for compound 4 lay 0.19 below the measured number; the measured number lies above the stated range.
By their numbers in this assay, from the lowest: compound 2; then compounds 4, 3 and 1 (each within the scatter of the next, the first and the last beyond it).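

Fluoro in place of hydrogen at this position, para to a large group and meta to the trifluoromethyl group, gives in this assay a number 0.18 higher from compound 2 to compound 4 (beyond the scatter). So one added atom on this ring is enough to shift the read-out, something the earlier compounds, which differ in more than one place, could not show. Nothing available explains the step.

Going by these compounds, it remains open whether chloro, methoxy or a nitrile at this position would give a similar step, and whether fluoro would act the same way with methyl in place of trifluoromethyl.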